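Fluoro to chloro on the aryl piperazine of compound 3

This account rests on a few compounds, and the source may have more. Where it says the series, first, only, none or still open, it means among the compounds named here.

Measured so far:
compound 1 `COc1ccc(-c2nc(C)oc2C(=O)N2CCN(c3cccc(Cl)c3)CC2)cc1` — "not active" (no number reported)
compound 2 `CC(=O)c1ccc(N2CCN(C(=O)c3oc(C)nc3-c3ccccc3)CC2)cc1` — "not active" (no number reported)
compound 3 `Cc1nc(-c2ccccc2)c(C(=O)N2CCN(c3cccc(F)c3)CC2)o1` — 45 nM

For the measured compounds named here, in a functional assay on HL-60 cells (Homo sapiens) for inhibition, read by MTT assay, with a stated time of 72 h (a higher number here means a weaker inhibitor, a lower number a stronger inhibitor), compound 3 gives 45 nM, the only number in this set; compound 1 and compound 2 are reported without a number. Compound 4 `Cc1nc(-c2ccccc2)c(C(=O)N2CCN(c3cccc(Cl)c3)CC2)o1` differs from compound 3 in one place: chloro in place of fluoro on an aromatic carbon. The change sits on an aromatic carbon of a six-membered aromatic ring of carbon only, meta to a large group, and is one heavy atom for one heavy atom. Going by the values given here, no pair of measured compounds shows this change alone, so nothing here tells its size. Compound 4 is expected to stay close to compound 3, with a step of a 1.3-fold higher number from compound 3 to compound 4 (0.12 log units; within the scatter) in this assay, within the usual scatter. The estimate for compound 4 is 60 nM, ranging from 20 nM to 250 nM.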

Compound 4, half-maximal inhibitory concentration: 39.2 nM
Beside the measured number, compound 4's estimate is 1.5-fold (0.18 log units) above it; low and high end bracket the measured number.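

In this assay the change reads as a 1.1-fold lower number from compound 3 to compound 4 (0.06 log units; within the scatter), so fluoro and chloro read alike at this place on the 3-fluorophenyl and 3-chlorophenyl rings. Compound 1 carries the same 3-chlorophenyl and adds a methoxy group to compound 4, yet compound 1 is reported as "not active" (no number reported) and no step can be read, so chloro alone does not go with that result. Nothing measured here gives a reason for either reading. Still open, on these data alone, is how a bromo, a trifluoromethyl or an amine would read at this place. As far as these compounds go, whether the methoxy group alone separates compound 1 from compound 4 also stays open.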